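The source may report more compounds than this note shows. Statements on the series, on what has been measured and on what is new or still open speak of the compounds shown alone.

Measured so far in a functional assay on DU-145 cells (Homo sapiens) for inhibition, read by trypan blue exclusion, with a stated time of 72 h; a lower number here means a stronger inhibitor, a higher number a weaker inhibitor:

Compound 1 `Cn1c(=O)c(S(=O)(=O)c2ccc(F)cc2F)cc2cnc(Nc3cccc4[nH]ccc34)nc21`: 750 nM
Compound 2 `Cn1c(=O)c(S(=O)(=O)c2ccc(F)cc2F)cc2cnc(Nc3ccc4cccc(O)c4n3)nc21`: 5000 nM

Compound 1 gives the lowest of the two numbers shown; its only neighbour is compound 2, and the step of a 6.7-fold higher number from compound 1 to compound 2 (0.82 log units; beyond the scatter) is the sole measured step in the series. That step changes the group on the aromatic nitrogen, not the group on the sulfonyl sulfur, so it does not bear on the change now considered.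

Compound 3 `Cn1c(=O)c(S(=O)(=O)c2ccc(Cl)cc2)cc2cnc(Nc3cccc4[nH]ccc34)nc21` keeps the indole of compound 1 and differs only on the sulfonyl sulfur: 4-chlorophenyl in place of 2,4-difluorophenyl on a sulfonyl sulfur. No measured pair in this series tests a change at that place, so nothing shown here can set the direction or size of the step. With no guide, the expectation for compound 3 is a number near that of compound 1, the step of a 1.2-fold higher number from compound 1 to compound 3 (0.08 log units; within the scatter) expected to stay within the scatter. Compound 3 is therefore estimated at 900 nM, with a range from 300 nM to 3000 nM.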

Compound 3, half-maximal inhibitory concentration: 5000 nM
For compound 3 the middle estimate is 5.6-fold (0.74 log units) below the measured one, outside the stated range (above it).
By their numbers in this assay, from the lowest: compound 1; then compounds 2 and 3 (each within the scatter of the next).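

The sulfonyl sulfur is a place where the aryl group matters in this assay: with the 1H-indol-4-yl group held fixed, 4-chlorophenyl in place of 2,4-difluorophenyl gives a 6.7-fold higher number from compound 1 to compound 3 (0.82 log units; beyond the scatter). Within the data shown here, this is the first measured change at this place, and its step lies beyond the scatter, so the two aryl groups are not interchangeable here. Nothing available explains the rise in the number.

The fluorines leave and the chlorine enters in one step, so the contribution of each remains unresolved. On these data alone, how an unsubstituted phenyl, a 4-methoxyphenyl or a straight alkyl chain on the sulfonyl sulfur would compare also remains open.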